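Exchanging a thiophene group: compound 2 to compound 3

The compounds below may be only part of what the source reports. "The series", "measured", "known", "first", "only" and "open" are said of these compounds alone.

Measured so far in a functional assay on K562 cells (Homo sapiens) for cytotoxicity, read by ELISA, with a stated time of 4 days; on this read-out higher numbers stand for weaker inhibition and lower numbers for stronger inhibition:
- compound 1 `Clc1ccc(-c2cc(-c3ccoc3)cc(-c3ccco3)n2)s1`: 16200 nM
- compound 2 `Cc1ccsc1-c1cc(-c2ccc(Cl)o2)cc(-c2ccco2)n1`: 10600 nM

Only these two compounds have been measured, and neither value can be separated from the other. In this assay compound 2 gives 10600 nM, and this lies within the usual scatter of the value for compound 1, 16200 nM. Compound 2 therefore stands level with compound 1 on the numbers available.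

The next compound is compound 3 `Clc1ccc(-c2cc(-c3ccco3)nc(-c3ccc(Cl)s3)c2)o1`. It differs from compound 2 at a single place: 5-chlorothiophen-2-yl in place of 3-methylthiophen-2-yl on an aromatic carbon. In words, 5-chlorothiophen-2-yl stands in place of 3-methylthiophen-2-yl on an aromatic carbon, next to the ring nitrogen.

For the measured compounds named here, no step from a single change has been measured in this small set, so nothing shows how sensitive the read-out is to such an exchange. With compound 1 at 16200 nM and compound 2 at 10600 nM, the data offer no reason to expect a large move in either direction. The expected change is a 1.1-fold higher number from compound 2 to compound 3 (0.05 log units; within the scatter), which is no step beyond the scatter.

For compound 3 the estimated value is 12000 nM, with an expected range from 4000 nM to 32000 nM.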

Compound 3, half-maximal inhibitory concentration: 22500 nM
The estimate for compound 3 lay 1.9-fold (0.27 log units) below the measured number; measured number inside the range.
By their numbers in this assay, from the lowest: compounds 2, 1 and 3 (each within the scatter of the next, the first and the last beyond it).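

For the compounds shown here, the exchange of 3-methylthiophen-2-yl for 5-chlorothiophen-2-yl, on an aromatic carbon next to the ring nitrogen, gives the first single change that can be read in this assay: a 2.1-fold higher number from compound 2 to compound 3 (0.33 log units; beyond the scatter), a modest step. Both groups hold 6 heavy atoms, one five-membered aromatic ring with 1 hetero atom, 0 hydrogen-bond donors and 1 hydrogen-bond acceptor, so the read-out can move at this position even when those counts stay the same. The other exchange, 5-chlorofuran-2-yl in place of furan-3-yl on an aromatic carbon, is a 1.4-fold higher number from compound 1 to compound 3 (0.14 log units; within the scatter), so it cannot be told apart from no change at all, and all three compounds remain weak on these numbers.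

Nothing among the data shown accounts for the step between the two thiophene groups. As far as these compounds go, it remains open whether an amine, a carboxylic acid or a longer chain on this aromatic carbon next to the ring nitrogen would shift the number further, and whether any such group could bring it well below the values of these three compounds.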